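The source may report more compounds than this note shows. Statements on the series, on what has been measured and on what is new or still open speak of the compounds shown alone.

Within the data shown here, in a functional assay on A549 cells (Homo sapiens) for cytotoxicity, read by resazurin assay, with a stated time of 72 h (on this read-out higher numbers stand for weaker inhibition and lower numbers for stronger inhibition), compound 1 `COCOc1cc(OC)cc(OC)c1C(C)=O` gives 16900 nM, while compound 2 `COCOc1cc(OC)cc(OC)c1C(=O)/C=C/c1ccccc1` gives 3500 nM, the lower of the two numbers so far. Compound 3 `COCOc1cc(OC)c(C(=O)/C=C/c2ccccc2)c(OCOC)c1` differs from compound 2 by one small change: methoxy in place of hydrogen on a saturated chain carbon bound to an oxygen on an aromatic ring. Put simply, this is methoxy in place of hydrogen on a saturated chain carbon bound to an oxygen on an aromatic ring, so a methoxy becomes a methoxymethoxy. Among the measured compounds shown here, the only measured step is a 4.8-fold lower number from compound 1 to compound 2 (0.68 log units; beyond the scatter), which put 2-phenylethenyl in place of methyl on a carbonyl carbon. That is a different change at a different place, so it gives no direct guide here. The expectation therefore starts from compound 2 at 3500 nM, with no step beyond the scatter expected in this assay. The estimated step is a 1.1-fold higher number from compound 2 to compound 3 (0.06 log units; within the scatter). Compound 3 is expected at about 4000 nM, within an estimated range of 1500 nM to 11000 nM.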

Compound 3, half-maximal inhibitory concentration: 4200 nM
For compound 3 the middle estimate is 1.1-fold (0.02 log units) below the measured one; measured number inside the range.
By their numbers in this assay, from the lowest: compounds 2 and 3 (each within the scatter of the next); then compound 1.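

In this assay, among these compounds, turning a methoxy into a methoxymethoxy gives a 1.2-fold higher number from compound 2 to compound 3 (0.08 log units; within the scatter), the first measured step at this position. Compounds 2 and 3 therefore cannot be told apart on this read-out, and the added methoxy leaves the number within the scatter, something the earlier step, made at a different place, could not show. No supporting measurement is available to explain this result. Still open, on these data alone, is whether another group at this position, such as a hydroxyl, an amine, a carboxylic acid or a longer chain, would move the number beyond the scatter. Also open, as far as these compounds go, is whether the same change would give so small a step on compound 1, which carries methyl in place of 2-phenylethenyl.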